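A few compounds are considered here, and "the series" means these few. Any claim that something is new, unique, unknown or untested is made for them only; others in the source may bear on it.

Compound 1 `Cn1c(-c2ccc(NC(=O)CSc3nc4ccccc4s3)cc2)nc(-c2ccccc2)c1-c1ccccc1` gave 66% in a functional assay on HT-29 cells (Homo sapiens) for cytotoxicity, read by MTT assay, with a stated time of 24 h, tested at 32 ug/mL; on this read-out lower numbers stand for a weaker effect and higher numbers for a stronger effect at the one concentration tested. Compound 2 `Cn1nnnc1SCC(=O)Nc1ccc(-c2nc(-c3ccccc3)c(-c3ccccc3)n2C)cc1` gave 84%. Compound 3 `CN(C)/C=C/N1CCN(CC(=O)Nc2ccc(-c3nc(-c4ccccc4)c(-c4ccccc4)n3C)cc2)CC1` gave 29.8%.

Compound 3 stands lowest of the three: the nearer measured compound is compound 1, as a number 36.2 percentage points lower from compound 1 to compound 3 (beyond the scatter) shows, and the furthest is compound 2, as a number 54.2 percentage points lower from compound 2 to compound 3 (beyond the scatter) shows. Compound 4 `Cc1ccc(CN2CCN(CC(=O)Nc3ccc(-c4nc(-c5ccccc5)c(-c5ccccc5)n4C)cc3)CC2)cc1` differs from compound 3 in one place: 4-methylbenzyl in place of 2-(dimethylamino)ethenyl on an amine nitrogen in a ring. For the measured compounds named here, no measured step changes the group on this ring nitrogen, so the two large steps into compound 3 only show that the compounds without the six-membered ring with two nitrogens scored higher. For compound 4 a moderate rise is therefore expected, a number 15.2 percentage points higher from compound 3 to compound 4 (beyond the scatter), with wide uncertainty. Compound 4 is estimated at 45%, between 20% and 75%.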

Compound 4, a percentage reported as activity, at one concentration (the size of the read-out at that concentration, not a potency): 42.3%
Estimate against measurement, compound 4: 2.7 percentage points above, and the stated range covers the measured number.
By their numbers in this assay, from the lowest: compound 3; then compound 4; then compound 1; then compound 2.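

Changing only the group on the ring nitrogen moves the result, with a number 12.5 percentage points higher from compound 3 to compound 4 (beyond the scatter) in this assay when 4-methylbenzyl replaces 2-(dimethylamino)ethenyl. For the compounds shown here, this is the first measured sign that this position responds to its substituent, and the rise comes with several changes at once: a six-membered aromatic ring of carbon enters, more heavy atoms are present, and the nitrogen of the old group leaves. Nothing shown explains the rise. Plain benzyl or a simple ethyl group on this nitrogen would help show which of these changes counts.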